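Cytotoxicity of two close analogues and a positional isomer

The source may report more compounds than this note shows. Statements on the series, on what has been measured and on what is new or still open speak of the compounds shown alone.

Compound 1 `Cc1ccc(-c2nn(-c3ccccc3)cc2-c2nc3ccccc3n2C(=O)c2ccccc2C)cc1` and compound 2 `Cc1cccc(C(=O)n2c(-c3cn(-c4ccccc4)nc3-c3ccc(C(F)(F)F)cc3)nc3ccccc32)c1` share one core and differ only in the group on the phenyl that carries the trifluoromethyl. In an ADME assay on HEK-293T cells (Homo sapiens) for cytotoxicity, read by MTT assay, with a stated time of 24 h (on this read-out lower numbers stand for higher toxicity in this test and higher numbers for lower toxicity in this test), compound 1 gives 176000 nM and compound 2 gives 154000 nM; the two values lie within the scatter of each other. Compound 3 `Cc1ccc(C(=O)n2c(-c3cn(-c4ccccc4)nc3-c3ccc(C(F)(F)F)cc3)nc3ccccc32)cc1` is not yet measured; it differs from compound 2 by 4-methylphenyl in place of 3-methylphenyl on a carbonyl carbon. Going by the values given here, no measured step of this kind exists in the set, so no shift beyond the scatter is expected: the step of a 1.0-fold higher number from compound 2 to compound 3 (0.02 log units; within the scatter) is an estimate of no change. Compound 3 is expected to give about 160000 nM, within 80000 nM to 320000 nM.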

Compound 3, half-maximal cytotoxic concentration: 169000 nM
For compound 3 the middle estimate is 1.1-fold (0.02 log units) below the measured one; low and high end bracket the measured number.
By their numbers in this assay, from the lowest: compounds 2, 3 and 1 (each within the scatter of the next).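

In this assay, going by these compounds alone, the exchange of 3-methylphenyl for 4-methylphenyl on a carbonyl carbon gives a 1.1-fold higher number from compound 2 to compound 3 (0.04 log units; within the scatter) and is the first step read at this position. With the same atoms joined differently, compound 2 and compound 3 are not told apart by this read-out. No measured evidence offers a reason for this result.

Only two places for a methyl on this phenyl can be compared in one step. Going by these compounds, whether an amine or a carboxylic acid on this phenyl would leave the read-out equally unmoved stays open.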